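The source may report more compounds than this note shows. Statements on the series, on what has been measured and on what is new or still open speak of the compounds shown alone.

Of the compounds shown here, three sharing one core have been tested in a functional assay on Z-138 cells (Homo sapiens) for antiproliferative activity, with a stated time of 72 h; on this read-out lower numbers stand for stronger inhibition and higher numbers for weaker inhibition. Compound 3 `Nc1ncnn2c([C@@H]3O[C@H](CO)[C@@H](O)[C@H]3O)cc(-c3ccc(Cl)cc3)c12` gives 40200 nM in this assay, the lowest of the two numbers recorded. Compound 1 `Nc1ncnn2c([C@@H]3O[C@H](CO)[C@@H](O)[C@H]3O)cc(C#Cc3cccs3)c12` gives 50100 nM, and the gap between them, a 1.2-fold lower number from compound 1 to compound 3 (0.10 log units; within the scatter), is too small to count as a difference. For compound 2 `Nc1ncnn2c([C@@H]3O[C@H](CO)[C@@H](O)[C@H]3O)cc(-c3ccccc3)c12` only a limit of the measurement is recorded, > 100000 nM, as noted in the limit of > 100000 nM in this assay, at which 1 of the 3 values shown sits.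

The new compound 4 `Nc1ncnn2c([C@@H]3O[C@H](CO)[C@@H](O)[C@H]3O)cc(/C=C/c3ccccc3)c12` differs from compound 3 in one place: 2-phenylethenyl in place of 4-chlorophenyl on an aromatic carbon. Two measured steps speak to this change. The first is an at least 2.4-fold lower number from compound 2 to compound 3 (0.39 log units; beyond the scatter), which shows that removing the chloro from the phenyl tends to push the number up. The second is an at least 1.9-fold higher number from compound 1 to compound 2 (0.30 log units; that floor lies within the scatter), a step whose floor lies within the scatter and so says little on its own. Compound 4 keeps its phenyl on a chain, as the 2-(thiophen-2-yl)ethynyl of compound 1 does, but gives up the chloro, so the loss of chloro is the main pull, pointing toward a higher number and a fair chance that only a limit is reported. The expected step is therefore a 1.9-fold higher number from compound 3 to compound 4 (0.27 log units; within the scatter). Compound 4 is estimated at 75000 nM, between 30000 nM and 180000 nM.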

Compound 4, half-maximal inhibitory concentration: 1300 nM
Beside the measured number, compound 4's estimate is 58-fold (1.76 log units) above it; the measured number lies below the stated range.
By their numbers in this assay, from the lowest: compound 4; then compounds 3 and 1 (each within the scatter of the next). At a limit, above all of these: compound 2.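

In this assay, within the data shown here, the aromatic carbon of the shared core proves far more responsive than the earlier compounds suggested: moving to the 2-phenylethenyl group gives a 31-fold lower number from compound 3 to compound 4 (1.49 log units; beyond the scatter) and a 39-fold lower number from compound 1 to compound 4 (1.59 log units; beyond the scatter) and an at least 76-fold lower number from compound 2 to compound 4 (1.88 log units; beyond the scatter) in this set of compounds. Among these compounds, until now the only step beyond the scatter was the modest one from adding a chloro to the phenyl, whereas compound 2 and compound 4 both carry an unsubstituted phenyl ring and differ by the double bond outside aromatic rings, so a large drop in the number can come without any chloro. The step from compound 2 is only a floor, since compound 2 has a limit of the measurement and not a number: the limit of > 100000 nM in this assay, at which 1 of the 4 values shown sits.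

The compounds shown cannot tell whether the double bond itself matters or whether any chain carrying the phenyl would do, and a saturated ethyl link or a longer chain would test that. From the compounds shown here alone, it also remains open how the number would respond to a chloro or an amine on the phenyl ring of compound 4.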